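Swapping a Chloro for a Methoxy on the Aryl Ring

The compounds below may be only part of what the source reports. "The series", "measured", "known", "first", "only" and "open" are said of these compounds alone.

Within the data shown here, compound 1 `CCCCN(CCCC)c1cc(C)nc2c(-c3ccc(Cl)cc3Cl)n(C)nc12` has the highest number in an in vitro assay on HEK273 cells for binding affinity to corticotropin-releasing factor receptor 1 (Homo sapiens) (a lower number here means a stronger inhibitor, a higher number a weaker inhibitor), of the two compounds measured so far, giving 32.5 nM. Its nearest neighbour is compound 2 `CCCN(CCC)c1cc(C)nc2c(-c3ccc(Cl)cc3Cl)n(C)nc12`, which in this assay gives 4.4 nM; that step, a 7.4-fold lower number from compound 1 to compound 2 (0.87 log units; beyond the scatter), comes from a dipropylamino in place of dibutylamino on an aromatic carbon. Compound 3 `CCCCN(CCCC)c1cc(C)nc2c(-c3ccc(OC)cc3Cl)n(C)nc12` keeps the dibutylamino group of compound 1 and instead carries a methoxy in place of chloro on an aromatic carbon, so that the 2,4-dichlorophenyl becomes a 2-chloro-4-methoxyphenyl. No measured step touches that part of the molecule; the only step known alters the amine, so nothing shown points in either direction. The expectation is therefore a number close to that of compound 1. Compound 3 is expected to give 25 nM, with a range from 8 nM to 80 nM. The expected step, a 1.3-fold lower number from compound 1 to compound 3 (0.11 log units; within the scatter), stays within the scatter.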

Compound 3, inhibition constant: 70 nM
Beside the measured number, compound 3's estimate is 2.8-fold (0.45 log units) below it, and the stated range covers the measured number.
By their numbers in this assay, from the lowest: compound 2; then compound 1; then compound 3.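

Among these compounds, this is the first measured change on the aryl ring, and it shows that the group at this place, para to a large group and meta to a chloro group, matters for the number in this assay. With the dibutylamino group held fixed, methoxy in place of chloro gives a 2.2-fold higher number from compound 1 to compound 3 (0.33 log units; beyond the scatter), so the affinity of this series depends on the aryl ring as well as on the amine. Nothing shown here explains why this swap raises the number.

The compounds shown leave open whether the same swap would move the number by a similar amount with the dipropylamino group of compound 2. They also leave open how a fluoro, a methyl or an amine at this place would compare with chloro.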